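Chain extension by two carbons on a cytotoxic pyrrolidine series

The compounds below may be only part of what the source reports. "The series", "measured", "known", "first", "only" and "open" are said of these compounds alone.

Measured compounds:
compound 1 `CCCCCCCCCCCCc1ccc(CO[C@@H]2CN[C@@H](CO)C2)cc1` gives 10100 nM
compound 2 `CCCCCCCCCCCCCCc1ccc(CO[C@@H]2CN[C@@H](CO)C2)cc1` gives 10500 nM
compound 3 `CCCC/C=C/c1ccc(CO[C@H]2CN[C@H](CO)C2)cc1` gives 5700 nM

In a functional assay on FL5.12 cells (Mus musculus) for cytotoxicity, read by flow cytometry, with a stated time of 48 h (a higher number here means a weaker inhibitor, a lower number a stronger inhibitor), compound 1 and compound 2 differ only by ethyl in place of hydrogen on a saturated chain carbon, ten or more bonds along the chain from an aromatic carbon; this gave a 1.0-fold higher number from compound 1 to compound 2 (0.02 log units; within the scatter). The difference between the core of compound 3 and the core of compound 1 is not broken down here; their values lie within the scatter of each other.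

Compound 4 `CCCCCC/C=C/c1ccc(CO[C@H]2CN[C@H](CO)C2)cc1` has not yet been measured. It differs from compound 3 by ethyl in place of hydrogen on a saturated chain carbon, four bonds along the chain from a double-bonded chain carbon, the same kind of change as the earlier one, though the place differs: four bonds along the chain from a double-bonded chain carbon here, at a different point of the saturated chain in the earlier step. Because the earlier step was a 1.0-fold higher number from compound 1 to compound 2 (0.02 log units; within the scatter), the step from compound 3 to compound 4 is expected to be small, about a 1.0-fold lower number from compound 3 to compound 4 (0.02 log units; within the scatter). Compound 4 is therefore estimated at 5500 nM, between 2500 nM and 11000 nM.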

Compound 4, half-maximal inhibitory concentration: 2400 nM
Estimate against measurement, compound 4: 2.3-fold (0.36 log units) above; measured number outside the range, below it.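

In this assay the new step is a 2.4-fold lower number from compound 3 to compound 4 (0.38 log units; beyond the scatter) and it cannot be told apart from the same change on the other core: the same change on two cores in this assay, a 1.0-fold higher number (0.02 log units; within the scatter) from compound 1 to compound 2 and a 2.4-fold lower number (0.38 log units; beyond the scatter) from compound 3 to compound 4, 2.5-fold (0.39 log units) apart, within the scatter of two such steps.
So nothing here shows that the core alters what this chain extension does, even though only the new step lies beyond the scatter. Nor does it show that the change carries over reliably, as each core offers just a single pair of compounds.

The compounds shown leave open whether a still longer chain on the core of compound 4 would lower the number further. They also leave open how either core would respond to an amine or a carboxylic acid on the chain.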